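Dimethylamino for Hydroxy on the Aryl Ring

This account rests on a few compounds, and the source may have more. Where it says the series, first, only, none or still open, it means among the compounds named here.

Compound 1 `CC1=CC[C@@H]([C@@](C)(O)CCCC(C)(C)NC(=S)N/N=C\c2ccccc2)CC1` is the parent of this small set. In a functional assay on NCI-H460 cells (Homo sapiens) for cytotoxicity, read by sulforhodamine B assay (on this read-out lower numbers stand for stronger inhibition of growth and higher numbers for weaker inhibition of growth), compound 1 gives only the limit > 100000 nM. For the measured compounds named here, compound 2 `CC1=CC[C@@H]([C@@](C)(O)CCCC(C)(C)NC(=S)N/N=C\c2ccc(O)cc2)CC1` carries a hydroxy on the aromatic ring, and in this assay compound 2 gives 20700 nM, the only number reported. The other value belongs to compound 1 and is a limit, as compound 1 sits at the limit of > 100000 nM in this assay, at which 1 of the 2 values shown sits. Going by the values given here, the step of an at least 4.8-fold lower number from compound 1 to compound 2 (0.68 log units; beyond the scatter) is the sole measured change here.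

Compound 3 `CC1=CC[C@@H]([C@@](C)(O)CCCC(C)(C)NC(=S)N/N=C\c2ccc(N(C)C)cc2)CC1` differs from compound 2 by dimethylamino in place of hydroxy on an aromatic carbon. Among the compounds with values here, the one measured step concerned hydroxy replacing hydrogen, so it speaks to this exchange only indirectly; the dimethylamino group keeps a hydrogen-bond acceptor but drops the donor. A modest step in either direction, or none beyond the scatter, is expected, and the estimate for compound 3 means a 1.7-fold higher number from compound 2 to compound 3 (0.23 log units; within the scatter). Compound 3 is therefore expected at 35000 nM, between 8000 nM and 150000 nM.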

Compound 3, concentration for total growth inhibition: > 100000 nM
Compound 3: a limit, no number; the forecaster's own chance of this, stated with the estimate: 30%; at least 2.8-fold (0.45 log units) between middle value and limit.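

In this assay, dimethylamino in place of hydroxy brings an at least 4.8-fold higher number from compound 2 to compound 3 (0.68 log units; beyond the scatter), so the gain seen with hydroxy on this aromatic carbon, para to a large group, does not carry over to dimethylamino. Compound 3 gives a limit and not a number, the same limit as compound 1: the limit of > 100000 nM in this assay, at which 2 of the 3 values shown sit. The step between the two limits cannot be read, so nothing separates the dimethylamino compound from the unsubstituted parent, and of the compounds shown only the one with hydroxy reaches a number.

From the compounds shown here alone, whether a methoxy or a primary amine on the same carbon would also give a number remains open. So does how a hydroxy elsewhere on the ring would compare with the one in compound 2.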